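A few compounds are considered here, and "the series" means these few. Any claim that something is new, unique, unknown or untested is made for them only; others in the source may bear on it.

Measured so far:
Compound 1 `O=C(NCCCCc1ccccc1)n1c(=O)oc2cc(Cl)ccc21` — in an assay on HEK293 cells for inhibition of acid ceramidase (Homo sapiens), with a stated time of 10 min (a lower number here means a stronger inhibitor, a higher number a weaker inhibitor), compound 1 gives 33 nM.
Compound 2 `O=C(NCCCCc1ccccc1)n1c(=O)oc2ccc([N+](=O)[O-])cc21` — in this assay compound 2 gives 3 nM.
Compound 3 `O=C(NCCCCc1ccc(F)cc1)n1c(=O)oc2ccccc21` — in this assay compound 3 gives 75 nM.

Among these three, compound 2 has the lowest number in this assay, and its gap to both compound 1 and compound 3 lies beyond the usual scatter, so it is the strongest inhibitor shown here.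

Compound 4 `O=C(NCCCCc1ccccc1)n1c(=O)oc2ccc(-c3ccc(F)cc3)cc21` has not yet been measured. It differs from compound 2 in one place: 4-fluorophenyl in place of nitro on an aromatic carbon. For the measured compounds named here, no step between measured compounds tests this kind of change, so the expectation rests on compound 2 alone and on the other two numbers. Compound 4 is expected to be a weaker inhibitor than compound 2, with a step of about a 6.7-fold higher number from compound 2 to compound 4 (0.82 log units; beyond the scatter) in this assay. The estimate for compound 4 is 20 nM, likely between 5 nM and 80 nM.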

Compound 4, half-maximal inhibitory concentration: 56 nM
Estimate against measurement, compound 4: 2.8-fold (0.45 log units) below; measured number inside the range.
By their numbers in this assay, from the lowest: compound 2; then compounds 1, 4 and 3 (each within the scatter of the next, the first and the last beyond it).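

Replacing nitro with 4-fluorophenyl at this position, in this assay, gives a 19-fold higher number from compound 2 to compound 4 (1.27 log units; beyond the scatter), so the group held here strongly affects inhibition. The change does not abolish it, though: compound 4 still gives 56 nM with the added aromatic ring in place. Nothing measured here explains why the step is so large.

As far as these compounds go, whether an amine, a methoxy group or a carboxylic acid at this position would stay close to compound 2 remains open. So does whether a plain phenyl ring would match 4-fluorophenyl.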